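Shortening the alkyl chain on the shared core

This account rests on a few compounds, and the source may have more. Where it says the series, first, only, none or still open, it means among the compounds named here.

Measured compounds:
compound 1 `CCCCCCCC1C(CO[C@@H]2O[C@@H]3CO[C@H](c4ccccc4)O[C@@H]3[C@H](OCc3ccccc3)[C@H]2O)N1S(=O)(=O)c1ccc(C)cc1` — an ADME assay on MRC5 cells (Homo sapiens) for cytotoxicity, read by MTT assay, with a stated time of 48 h; a higher number here means a weaker inhibitor, a lower number a stronger inhibitor: > 1000000 nM
compound 2 `CCCCCCCCCCCCCCC1(CO[C@@H]2O[C@@H]3CO[C@H](c4ccccc4)O[C@@H]3[C@H](OCc3ccccc3)[C@H]2OCc2ccccc2)CN1S(=O)(=O)c1ccc(C)cc1` — this assay: 1000000 nM

For the measured compounds named here, compound 2 holds the only plain number in this assay among the two measured compounds. Compound 1 is reported only as a limit of this assay, > 1000000 nM, and not as a number; the limit of > 1000000 nM in this assay, at which 1 of the 2 values shown sits, describes where that limit sits. Going by the values given here, compound 1 and compound 2 also differ from each other in more than one place, so no single step between them is counted here, and their two values say only that neither compound shows appreciable cytotoxicity in this assay.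

Compound 3 `CCCCCCCCCC1(CO[C@@H]2O[C@@H]3CO[C@H](c4ccccc4)O[C@@H]3[C@H](OCc3ccccc3)[C@H]2OCc2ccccc2)CN1S(=O)(=O)c1ccc(C)cc1` is not yet measured. It differs from compound 2 in one place: hydrogen in place of pentyl on a saturated chain carbon, nine bonds along the chain from a saturated ring carbon. Among the compounds with values here, since no step between measured compounds is available, the expectation rests on the position of compound 2 alone. The step from compound 2 to compound 3 is expected to be no change at the digits printed from compound 2 to compound 3 (within the scatter), that is, none beyond the usual scatter. Compound 3 is therefore estimated at 1000000 nM, within 500000 nM to 2000000 nM, with a fair chance that this assay again reports only a limit.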

Compound 3, half-maximal inhibitory concentration: 575000 nM
Compound 3: the middle estimate sits 1.7-fold (0.24 log units) above what was measured; low and high end bracket the measured number.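

Hydrogen in place of pentyl on a saturated chain carbon, nine bonds along the chain from a saturated ring carbon, gives the first single-place step in the series: in this assay, the result is a 1.7-fold lower number from compound 2 to compound 3 (0.24 log units; within the scatter). The chain of compound 2 can therefore lose its pentyl portion without a change in cytotoxicity beyond the usual scatter, which the earlier pair, differing in more than one place, could not show. Compound 1 remains a limit and not a number, which marks the top of the range in which this comparison lies: the limit of > 1000000 nM in this assay, at which 1 of the 3 values shown sits.

One step within the scatter describes only this one shortening of the chain, so it gives no trend along the chain and says nothing about how far the chain could be cut before the reading moves. Also open, from the compounds shown here alone, is whether a much shorter propyl chain, or a chain ending in an amine or a carboxylic acid, would keep the value in the same range on the shared core.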